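Ring-fused amide series: hydroxy anilide with nonanoyl chain

The source may report more compounds than this note shows. Statements on the series, on what has been measured and on what is new or still open speak of the compounds shown alone.

Measured so far in a functional assay on PC-3 cells (Homo sapiens) for cytotoxicity, read by sulforhodamine B assay, with a stated time of 72 h; on this read-out lower numbers stand for stronger inhibition of growth and higher numbers for weaker inhibition of growth:
compound 1 `CC(=O)N1c2ccccc2CCC1C(=O)Nc1ccccc1O`: 70700 nM
compound 2 `O=C(Nc1ccccc1O)C1CCc2ccccc2N1C(=O)c1ccc(Cl)cc1`: 25100 nM
compound 3 `CCCCCCCCC(=O)N1c2ccccc2CCC1C(=O)Nc1ccccc1C(F)(F)F`: 4320 nM

Compound 3 gives the lowest number of the three in this assay; compound 2 sits above it and compound 1 furthest above it, both gaps beyond the scatter. Compound 4 `CCCCCCCCC(=O)N1c2ccccc2CCC1C(=O)Nc1ccccc1O` is not yet measured. It differs from compound 3 in one place: hydroxy in place of trifluoromethyl on an aromatic carbon, the anilide ring thus carrying a hydroxy ortho to a large group, as in compounds 1 and 2.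

For the measured compounds named here, no measured step exchanges trifluoromethyl for hydroxy, so nothing bears on this change directly. Going by the values given here, the only counted step, a 2.8-fold lower number from compound 1 to compound 2 (0.45 log units; beyond the scatter), concerns the group on the carbonyl carbon and leaves the hydroxy anilide untouched; it shows that this part of the series moves in a modest way. The two hydroxy anilides so far stand well above compound 3, while the nonanoyl chain in compound 4 is kept from compound 3.

For compound 4 the number in this assay is expected to rise, with an estimated step of a 3.2-fold higher number from compound 3 to compound 4 (0.51 log units; beyond the scatter). Compound 4 is estimated at 14000 nM, within 4000 nM to 45000 nM.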

Compound 4, concentration for 50% growth inhibition: 45200 nM
The estimate for compound 4 lay 3.2-fold (0.51 log units) below the measured number; the measured number lies above the stated range.
By their numbers in this assay, from the lowest: compound 3; then compounds 2, 4 and 1 (each within the scatter of the next, the first and the last beyond it).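

Trifluoromethyl on the anilide ring is what separates these compounds in this assay: with the nonanoyl chain held, hydroxy in its place gives the only large step in the series (a 10-fold higher number from compound 3 to compound 4 (1.02 log units; beyond the scatter)). With the hydroxy anilide held, the group on the carbonyl carbon leaves the read-out within the scatter, both for octyl in place of 4-chlorophenyl (a 1.8-fold higher number from compound 2 to compound 4 (0.26 log units; within the scatter)) and for heptyl in place of hydrogen (a 1.6-fold lower number from compound 1 to compound 4 (0.19 log units; within the scatter)), so the nonanoyl chain alone does not give the low number of compound 3. Nothing at hand accounts for the size of the step from trifluoromethyl to hydroxy.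

Open, from the compounds shown here alone, is whether trifluoromethyl has the same effect with acetyl or 4-chlorobenzoyl on the ring nitrogen. Also open, going by these compounds, is how methoxy, chlorine or an amine on the same aromatic carbon would read.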